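A few compounds are considered here, and "the series" means these few. Any claim that something is new, unique, unknown or untested is made for them only; others in the source may bear on it.

Measured compounds:
compound 1, `Cc1cccc(C(=O)N2CCn3nc(-c4ccc(F)cn4)cc3C2)c1`: 150 nM
compound 2, `COc1cccc(C(=O)N2CCn3nc(-c4ccc(F)cn4)cc3C2)c1`: 482 nM
compound 3, `N#Cc1cccc(C(=O)N2CCn3nc(-c4ccc(F)cn4)cc3C2)c1`: > 10000 nM

In a functional assay on HEK293 cells for negative allosteric modulation of metabotropic glutamate receptor 5 (Homo sapiens), read by calcium flux, with a stated time of 20 min (a lower number here means a stronger inhibitor, a higher number a weaker inhibitor), compound 3 stands at the limit of the assay, (the limit of > 10000 nM in this assay, at which 1 of the 3 values shown sits), so for compound 3 only a limit and no number is known. The step to compound 4, `Cc1cc(F)cc(C(=O)N2CCn3nc(-c4ccc(F)cn4)cc3C2)c1`, is 3-fluoro-5-methylphenyl in place of 3-cyanophenyl on a carbonyl carbon. Going by the values given here, two measured steps bear on it, both concerning the cyano group: an at least 66-fold higher number from compound 1 to compound 3 (1.82 log units; beyond the scatter) and an at least 20-fold higher number from compound 2 to compound 3 (1.31 log units; beyond the scatter). Both are large and both run toward a higher number when the cyano enters. Compound 4 keeps the methyl of compound 1, which in this assay gives 150 nM. The change to compound 4 takes the cyano away again, so a large step toward a lower number is expected, an at least 55-fold lower number from compound 3 to compound 4 (1.74 log units; beyond the scatter). Compound 4 is therefore expected to give 180 nM, with a range from 60 nM to 600 nM.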

Compound 4, half-maximal inhibitory concentration: 197 nM
Compound 4: the middle estimate sits 1.1-fold (0.04 log units) below what was measured; the range from low to high includes it.
By their numbers in this assay, from the lowest: compounds 1 and 4 (each within the scatter of the next); then compound 2. At a limit, above all of these: compound 3.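

In this assay, adding a fluoro to the methyl-bearing phenyl on the carbonyl carbon gives a 1.3-fold higher number from compound 1 to compound 4 (0.12 log units; within the scatter), so the added fluoro brings no change that can be told from scatter. The 3-fluoro-5-methylphenyl group gives a 2.4-fold lower number from compound 2 to compound 4 (0.39 log units; beyond the scatter) and an at least 50-fold lower number from compound 3 to compound 4 (1.70 log units; beyond the scatter). Compound 3 stands at a limit, so the second of these steps is a bound and not a measured size: the limit of > 10000 nM in this assay, at which 1 of the 4 values shown sits.

Going by these compounds, whether a chloro or trifluoromethyl in place of the fluoro would give a similar value stays open. So does how an amine or a carboxylic acid would fare on this ring.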